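The source may report more compounds than this note shows. Statements on the series, on what has been measured and on what is new or still open speak of the compounds shown alone.

Working notes on the series built on the core of compound 1 `Cc1cc(NC(=O)Nc2ccc(F)cc2)c2ccccc2n1`. In an ADME assay on HEK293 cells (Homo sapiens) for cytotoxicity, with a stated time of 72 h (on this read-out lower numbers stand for an effect already at smaller amounts and higher numbers for an effect only at larger amounts of compound), compound 1 gives > 25000 nM, which is a limit and not a number. Compound 2 `Cc1cc(NC(=O)Nc2ccc(N(C)C)cc2)c2ccccc2n1` gives > 25000 nM, also a limit. Going by the values given here, compound 3 `Cc1cc(NC(=O)Nc2ccc(C(F)(F)F)cc2)c2ccccc2n1` gives 25000 nM, the only actual number so far. The rest of the series stands at the limit of > 25000 nM in this assay, at which 2 of the 3 values shown sit.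

Compound 4 `Cc1cc(NC(=O)Nc2ccc(SC(F)(F)F)cc2)c2ccccc2n1` differs from compound 3 by (trifluoromethyl)sulfanyl in place of trifluoromethyl on an aromatic carbon, para to a large group: (trifluoromethyl)sulfanyl in place of trifluoromethyl on an aromatic carbon.

Three measured exchanges at that same aromatic carbon bear on this change. The first is a number no higher from compound 1 to compound 3 (the limit leaves the size open). The second is a number no higher from compound 2 to compound 3 (the limit leaves the size open). The third is a step that the two limits leave unreadable from compound 1 to compound 2. None of the three has a readable size, so no measured size carries over to the new exchange. Among the compounds with values here, the only direction they offer is the one seen in compound 3 at 25000 nM, where a number first appears in this assay. A small move to a lower number is therefore expected, and a result within the scatter would fit equally well. The expected step is a 1.3-fold lower number from compound 3 to compound 4 (0.10 log units; within the scatter). For compound 4 the estimated value is 20000 nM, with an expected range of 10000 nM to 25000 nM.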

Compound 4, half-maximal effective concentration: 13000 nM
Compound 4: middle estimate off by 1.5-fold (0.19 log units), on the high side; the range from low to high includes it.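

In this assay, going by these compounds alone, the exchange of trifluoromethyl for (trifluoromethyl)sulfanyl gives the first step with a readable size at this aromatic carbon (a 1.9-fold lower number from compound 3 to compound 4 (0.28 log units; within the scatter)), so the added sulfur does not separate compound 4 from compound 3 on this read-out. Two further steps are readable only as floors (an at least 1.9-fold lower number from compound 2 to compound 4 (0.28 log units; that floor lies within the scatter) and an at least 1.9-fold lower number from compound 1 to compound 4 (0.28 log units; that floor lies within the scatter)), and neither floor establishes a real difference, though the true size of each may be larger. Compound 1 and compound 2 give limits and not numbers: the limit of > 25000 nM in this assay, at which 2 of the 4 values shown sit.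

Within the data shown here, every readable step at this position so far lies within the scatter, and whether any group on this aromatic carbon can give a step beyond it remains open. From the compounds shown here alone, how a carboxylic acid, a primary amine or a longer perfluoroalkyl chain at this place would read in this assay also stays open.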